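The source may report more compounds than this note shows. Statements on the series, on what has been measured and on what is new or still open speak of the compounds shown alone.

Measured in a functional assay on MCF7 cells (Homo sapiens) for inhibition, read by CCK-8 assay, with a stated time of 48 h; a lower number here means a stronger inhibitor of growth, a higher number a weaker inhibitor of growth:

- Compound 1 (`Cc1ccccc1Nc1nc(NC2CCCCC2)ncc1Cl`) gives > 100000 nM, which is a limit of the assay and not a number.
- Compound 2 (`Cc1ccc(CNc2nc(Nc3ccc(N4CCN(C)CC4)cn3)ncc2Cl)cc1`) gives 38100 nM.

Within the data shown here, compound 2 is the only compound in this small set with an actual number in this assay, since the one other result is a limit. With a single number, there is no spread of values against which to place it.

Compound 3 (`Cc1ccc(Nc2nc(Nc3ccc(N4CCN(C)CC4)cn3)ncc2Cl)cc1`) has not yet been measured. It departs from compound 2 in one place, on a nitrogen on an aromatic ring, where 4-methylphenyl stands in place of 4-methylbenzyl: 4-methylphenyl in place of 4-methylbenzyl on a nitrogen on an aromatic ring.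

Among the measured compounds shown here, no measured pair of compounds shows what a change of this kind does, so the expectation rests on the structural change alone and is uncertain. A step towards stronger growth inhibition, beyond the usual scatter, is expected, although a step too small to distinguish from the scatter remains possible. The expected change is a 6.4-fold lower number from compound 2 to compound 3 (0.80 log units; beyond the scatter). For compound 3 the estimated value is 6000 nM, with an expected range from 700 nM to 45000 nM.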

Compound 3, concentration for 50% growth inhibition: 11400 nM
The estimate for compound 3 lay 1.9-fold (0.28 log units) below the measured number, and the stated range covers the measured number.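

In this assay, the change from (4-methylbenzyl)amino to (4-methylphenyl)amino gives a 3.3-fold lower number from compound 2 to compound 3 (0.52 log units; beyond the scatter), which shows that growth inhibition responds to the group on this nitrogen. The leaving group has 8 heavy atoms and the entering group 7, and both carry one six-membered aromatic ring of carbon only and no hydrogen-bond donors or acceptors, so a difference of this size in the group is enough to move the number beyond the scatter, although compound 3 still gives 11400 nM. Compound 1 cannot be set against either compound, since it differs in more than one place and its result is a limit of the assay and not a number: the limit of > 100000 nM in this assay, at which 1 of the 3 values shown sits.

The compounds shown leave open whether the step comes from the shorter link itself or would also follow from other groups on this nitrogen, such as 2-phenylethyl, or a phenyl ring carrying chlorine or methoxy in place of methyl. They also leave open whether the same change would give a step of similar size on a different core.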